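Swapping a pyrimidine for a fluorophenyl on a fused core

A few compounds are considered here, and "the series" means these few. Any claim that something is new, unique, unknown or untested is made for them only; others in the source may bear on it.

Of the compounds shown here, two have been measured in an ADME assay on microsomes from liver (Homo sapiens) for metabolic stability, using NADPH, with a stated time of 30 min, in the presence of a further agent that is not named here; a higher number here means that more of the compound is left, a lower number that less of the compound is left. Compound 1, `CC(C)[C@H]1Cc2n[nH]cc2[C@@H](C(C)C)N1S(=O)(=O)c1ccc(C(F)(F)F)cc1`, gives 10%, so little of it survives the incubation. Compound 2, `O=S(=O)(c1ccc(Cl)cc1)N1Cc2c[nH]nc2CC1c1cncnc1`, gives 67% in this assay, and this is the higher of the two numbers shown, with compound 1 the nearest neighbour at a figure lower by a margin that lies beyond the scatter of repeated measurements. The two compounds differ in several places at once, so no single structural step can be read from them.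

Compound 3, `O=S(=O)(c1ccc(Cl)cc1)N1Cc2c[nH]nc2CC1c1ccc(F)cc1`, has not yet been measured in this assay. It differs from compound 2 in one place: 4-fluorophenyl in place of pyrimidin-5-yl on a saturated ring carbon. A plain carbon ring with a fluorine thus replaces a ring carrying two nitrogen atoms on the saturated ring carbon of the shared core.

With only compound 2 as a direct point of comparison, the expected step in this assay from compound 2 to compound 3 is a moderate fall, a number 22 percentage points lower from compound 2 to compound 3 (beyond the scatter), somewhat larger than the scatter. Compound 3 is therefore estimated to give 45% in this assay, with a range from 20% to 70%.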

Compound 3, percent of the compound remaining: 6%
Compound 3: middle estimate off by 39 percentage points, on the high side; the whole stated range lies above it.
By their numbers in this assay, from the lowest: compounds 3 and 1 (each within the scatter of the next); then compound 2.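

For the compounds shown here, the exchange of pyrimidin-5-yl for 4-fluorophenyl is the first change in one place alone, and in this assay it gives a number 61 percentage points lower from compound 2 to compound 3 (beyond the scatter) as a large step. The rest of the two compounds is the same, so this step belongs to the exchange at this saturated ring carbon, next to the ring nitrogen, where a ring with two nitrogen atoms and two hydrogen-bond acceptors gives way to a carbon-only ring bearing fluorine and no acceptors. No measurement at hand says why the number falls so far or which part of compound 3 is lost during the incubation.

The compounds shown leave open whether the step follows the loss of the ring nitrogen atoms, the arrival of the fluorine or both, a question that plain phenyl and pyridin-3-yl, with its single ring nitrogen, could help to separate. They also leave open whether pyrimidin-5-yl would give a step of similar size on a core carrying a different group on the sulfonyl ring, such as trifluoromethyl in place of chlorine.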